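The source may report more compounds than this note shows. Statements on the series, on what has been measured and on what is new or still open speak of the compounds shown alone.

Compound 1 `Cc1cc(Nc2nc(Nc3ccccc3)nc3[nH]ncc23)n[nH]1` gives 5900 nM in an assay on isolated protein for inhibition of serine/threonine-protein kinase PAK 4 (Homo sapiens), read by HTRF, with a stated time of 60 min; a higher number here means a weaker inhibitor, a lower number a stronger inhibitor.
Compound 2 `Cc1cc(Nc2nc(NCc3cccc(F)c3)nc3[nH]ncc23)n[nH]1` gives 458 nM in this assay.
Compound 3 `Cc1cc(Nc2nc(NCc3cccc(Br)c3)nc3[nH]ncc23)n[nH]1` gives 4340 nM in this assay.

Compound 3 holds the second highest of these three numbers; the gap here is a 1.4-fold lower number from compound 1 to compound 3 (0.13 log units; within the scatter), while compound 2 lies well apart, as a 9.5-fold higher number from compound 2 to compound 3 (0.98 log units; beyond the scatter) shows. Compound 4 `Cc1cc(Nc2nc(NCc3ccc(F)cc3F)nc3[nH]ncc23)n[nH]1` differs from compound 3 by 2,4-difluorophenyl in place of 3-bromophenyl on a saturated chain carbon bound to a nitrogen on an aromatic ring. The step that bears most on this change is a 9.5-fold higher number from compound 2 to compound 3 (0.98 log units; beyond the scatter), where fluoro in place of bromo gave a clearly lower number; a 13-fold lower number from compound 1 to compound 2 (1.11 log units; beyond the scatter) likewise shows a 3-fluorobenzyl giving a much lower number than plain phenyl. A fluorine-bearing ring returns in compound 4, now with two fluorines, so the number for compound 4 is expected to fall, giving a 4.8-fold lower number from compound 3 to compound 4 (0.68 log units; beyond the scatter). The estimate for compound 4 is 900 nM, with a range from 250 nM to 3500 nM.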

Compound 4, half-maximal inhibitory concentration: 96.1 nM
The estimate for compound 4 lay 9.4-fold (0.97 log units) above the measured number; measured number outside the range, below it.
By their numbers in this assay, from the lowest: compound 4; then compound 2; then compounds 3 and 1 (each within the scatter of the next).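

Moving from 3-fluorophenyl to 2,4-difluorophenyl gives a 4.8-fold lower number from compound 2 to compound 4 (0.68 log units; beyond the scatter) in this assay, so the ring on this chain carbon still responds to a change among fluorinated rings. Replacing 3-bromophenyl gives a 45-fold lower number from compound 3 to compound 4 (1.65 log units; beyond the scatter), a larger step than either earlier benzyl comparison suggested. The number and the placing of the fluorines change together here, so their contributions cannot be separated, and no measurement shown explains the drop.

On these data alone, whether a single fluorine placed differently would do as well remains open. So does the effect of a methoxy group on this ring or a longer chain before it.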